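Substituent on the triazole carbon: aryl removed, butyl added

The source may hold more compounds than are shown below. What is called first, only, known or untested is meant among the compounds shown, and "the series" means these compounds.

In a functional assay on HepG2 cells (Homo sapiens) for antiproliferative activity, read by MTT assay, with a stated time of 72 h (a lower number here means a stronger inhibitor, a higher number a weaker inhibitor), compound 1 `O=C1O[C@H]([C@@H](O)Cn2cc(-c3cc(F)cc(F)c3)nn2)C(OCc2ccccc2)=C1OCc1ccccc1` gives 11600 nM and compound 2 `CCCCCc1ccc(-c2cn(C[C@H](O)[C@H]3OC(=O)C(OCc4ccccc4)=C3OCc3ccccc3)nn2)cc1` gives 7460 nM. Compound 3 `O=C1O[C@H]([C@@H](O)Cn2ccnn2)C(OCc2ccccc2)=C1OCc1ccccc1`, with hydrogen on the aromatic carbon, reaches only the limit of this assay, > 100000 nM. Compound 3 therefore stands at the weak end of the numbers shown: an at least 8.6-fold higher number from compound 1 to compound 3 (0.93 log units; beyond the scatter), and an at least 13-fold higher number from compound 2 to compound 3 (1.12 log units; beyond the scatter), while a 1.6-fold lower number from compound 1 to compound 2 (0.19 log units; within the scatter). Compound 4 `CCCCc1cn(C[C@H](O)[C@H]2OC(=O)C(OCc3ccccc3)=C2OCc2ccccc2)nn1` differs from compound 3 by butyl in place of hydrogen on an aromatic carbon; the entering group has no ring. Among the compounds with values here, the two measured steps to compound 3 show that a group on this carbon lowers the number, but both groups are aromatic, and no step with a chain has been measured. The expected step is an at least 2.5-fold lower number from compound 3 to compound 4 (0.39 log units; beyond the scatter), a partial recovery only. Compound 4 is thus expected to give about 40000 nM in this assay, between 12000 nM and 150000 nM.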

Compound 4, half-maximal inhibitory concentration: 32800 nM
Compound 4: the middle estimate sits 1.2-fold (0.09 log units) above what was measured; the measured number falls inside the stated range.
By their numbers in this assay, from the lowest: compounds 2 and 1 (each within the scatter of the next); then compound 4. At a limit, above all of these: compound 3.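

Butyl on this aromatic carbon gives an at least 3.0-fold lower number from compound 3 to compound 4 (0.48 log units; beyond the scatter) in this assay and so a ring in the entering group is not required for a measurable number. Butyl still falls short of both aryl groups, with a 4.4-fold higher number from compound 2 to compound 4 (0.64 log units; beyond the scatter) and a 2.8-fold higher number from compound 1 to compound 4 (0.45 log units; beyond the scatter) in the same read-out. The first of these steps is a bound only, compound 3 being at a limit: the limit of > 100000 nM in this assay, at which 1 of the 4 values shown sits.

Open, from the compounds shown here alone, is whether the gap to the aryl groups reflects the ring or the chain length alone. A longer chain such as octyl, or a butyl chain ending in an amine or a carboxylic acid, would test this.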